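Carbamoyl-fluorophenyl ether in the tetramethyl-pentanone phenol series

The source may report more compounds than this note shows. Statements on the series, on what has been measured and on what is new or still open speak of the compounds shown alone.

Measured compounds:
compound 1 `Cc1c(OCCCCOc2cncc(C(=O)O)c2)ccc(C(=O)CC(C)(C)C)c1O`, 180 nM
compound 2 `Cc1c(OCCCCOc2ccc(C(=O)O)c(F)c2)ccc(C(=O)CC(C)(C)C)c1O`, 1110 nM
compound 3 `COc1ccc(OCCCCOc2ccc(C(=O)CC(C)(C)C)c(O)c2C)cc1`, "not active" (no number reported)

In an assay for positive allosteric modulation of metabotropic glutamate receptor 3 (Rattus norvegicus) (a higher number here means that more compound is needed for the effect, a lower number that less compound is needed), compound 3 stands outside the measured range: it is recorded as not active, and no figure is attached to it, so its distance to compound 1 or compound 2 cannot be stated. Compound 4 `Cc1c(OCCCCOc2ccc(F)c(C(N)=O)c2)ccc(C(=O)CC(C)(C)C)c1O` is the next member, and its change from compound 3 is 3-carbamoyl-4-fluorophenyl in place of 4-methoxyphenyl on an oxygen on a saturated carbon. Among the compounds with values here, the one measured step that bears on this position is a 6.2-fold higher number from compound 1 to compound 2 (0.79 log units; beyond the scatter), where a carboxy-bearing fluorophenyl replaced a carboxy-bearing pyridinyl. Compound 4 carries a fluorophenyl too, but with a carbamoyl group rather than a carboxy group, and compound 3 shows that a methoxyphenyl at this place gives no measurable effect. The expectation is therefore a return from inactivity to a measurable but weak number in this assay, most likely weaker than compound 2 shows with 1110 nM. For compound 4 the estimate is 3000 nM, within 800 nM to 15000 nM.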

Compound 4, half-maximal effective concentration: "not active" (no number reported)
No number was reported for compound 4; no gap can be computed for the estimate.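

In this assay compound 3 and compound 4 are both recorded as not active with no number attached, so no step can be read between them. Nothing shown offers an explanation for this result. The compounds shown leave open how far compound 3 and compound 4 lie from compound 1 and compound 2.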